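Swapping a sulfonyl for a methoxy on compound 1

The source may hold more compounds than are shown below. What is called first, only, known or untested is meant among the compounds shown, and "the series" means these compounds.

Compound 1, with the structure `Cc1c(C(=O)NCCCN2CCN(C)CC2)c(-c2cccc(N3CCN(c4ccc(NS(=O)(=O)c5cccc(S(=O)(=O)C6CC6)c5)cc4)CC3)c2)c(-c2ccc(Cl)cc2)n1C`, was tested in an assay for binding affinity to Apoptosis regulator Bcl-2 (Homo sapiens), read by fluorescence polarization, with a stated time of 2 h (on this read-out lower numbers stand for stronger inhibition and higher numbers for weaker inhibition), where compound 1 gives 218 nM. Of the two numbers measured here, this is the higher one. The other measured compound, compound 2 with the structure `Cc1c(C(=O)O)c(-c2cccc(N3CCN(c4ccc(NS(=O)(=O)c5ccc(N[C@H](CCN6CCCC6)CSc6ccccc6)c(S(=O)(=O)C(F)(F)F)c5)cc4)CC3)c2)c(-c2ccc(Cl)cc2)n1C`, gives 1.8 nM in this assay, a far lower number that lies beyond the scatter; compound 2 differs from compound 1 in several places at once, so no single step can be read from the pair.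

Compound 3, with the structure `COc1cccc(S(=O)(=O)Nc2ccc(N3CCN(c4cccc(-c5c(C(=O)NCCCN6CCN(C)CC6)c(C)n(C)c5-c5ccc(Cl)cc5)c4)CC3)cc2)c1`, has not yet been measured. It arises from compound 1 by one change: methoxy in place of cyclopropylsulfonyl on an aromatic carbon. In words, a methoxy takes the place of the cyclopropylsulfonyl on an aromatic carbon, meta to a large group, so that a 3-(cyclopropylsulfonyl)phenyl becomes a 3-methoxyphenyl.

Within the data shown here, no measured pair shows this exact change. The step from compound 1 to compound 3 is expected to be modest, toward a somewhat higher number, a 2.3-fold higher number from compound 1 to compound 3 (0.36 log units; beyond the scatter). Compound 3 is therefore estimated to give 500 nM in this assay, with a range from 150 nM to 1800 nM.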

Compound 3, inhibition constant: 207 nM
Compound 3: the middle estimate sits 2.4-fold (0.38 log units) above what was measured; the measured number falls inside the stated range.
By their numbers in this assay, from the lowest: compound 2; then compounds 3 and 1 (each within the scatter of the next).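

In this assay, putting a methoxy in place of the cyclopropylsulfonyl on this aromatic carbon gives a 1.1-fold lower number from compound 1 to compound 3 (0.02 log units; within the scatter), so compound 1 and compound 3 read alike. The 3-(cyclopropylsulfonyl)phenyl and the 3-methoxyphenyl differ considerably on paper: the group that leaves has 6 heavy atoms, a three-membered ring and 2 hydrogen-bond acceptors, whereas the group that enters has 2 heavy atoms, no ring and 1 hydrogen-bond acceptor. On the shared core of these two compounds, that difference in size and make-up does not separate them in this read-out, and no measurement at hand offers an explanation for this.

Two groups at one position cannot show how far this tolerance extends, so a nitrile, a primary amine or a longer chain such as a butoxy on the same aromatic carbon remains an open case. From the compounds shown here alone, it is also open whether a methoxy and a cyclopropylsulfonyl would still read alike on a core that differs elsewhere from that of compound 1.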